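A few compounds are considered here, and "the series" means these few. Any claim that something is new, unique, unknown or untested is made for them only; others in the source may bear on it.

Three ureas on the shared core of compound 1 `CC(=O)Nc1cc(NC(=O)Nc2ccc(Cl)c(C(F)(F)F)c2)ccc1C` have been measured in a functional assay on A375P cells (Homo sapiens) for antiproliferative activity; a higher number here means a weaker inhibitor, a lower number a stronger inhibitor. Compound 1 gives 1100 nM. Compound 2 `CC(=O)Nc1cc(NC(=O)Nc2cc(F)cc(C(F)(F)F)c2)ccc1C` reaches only > 30000 nM, which is a limit of the assay rather than a number. Compound 3 `CC(=O)Nc1cc(NC(=O)Nc2cccc(C(C)=O)c2)ccc1C` gives 22100 nM. Of the two values that are numbers, compound 3 therefore stands at the higher, weaker end, and its gap to compound 1 is well beyond the scatter of repeated measurements. The third value is the limit of > 30000 nM in this assay, at which 1 of the 3 values shown sits.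

Compound 4 `CC(=O)Nc1cc(NC(=O)Nc2cccc(Oc3ccccc3)c2)ccc1C` has not yet been measured. It differs from compound 3 by phenoxy in place of acetyl on an aromatic carbon. No measured pair among these compounds changes only this position, so the size of the step can only be expected, not read off. The step from compound 3 to compound 4 is expected to be a 3.7-fold lower number from compound 3 to compound 4 (0.57 log units; beyond the scatter), a moderate move toward stronger inhibition, since compound 1 at 1100 nM shows that this core can reach far lower numbers with a different substitution pattern on that ring. Compound 4 is accordingly expected to give 6000 nM in this assay, with a plausible range from 1200 nM to 30000 nM.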

Compound 4, half-maximal inhibitory concentration: > 30000 nM
Compound 4: only a limit was reported (the forecaster's own chance of this, stated with the estimate: 15%); middle value at least 5.0-fold (0.69 log units) from the limit.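

Going by these compounds, replacing acetyl with phenoxy, on an aromatic carbon meta to a large group, brings in a six-membered aromatic ring of carbon only and gives an at least 1.3-fold higher number from compound 3 to compound 4 (0.13 log units; that floor lies within the scatter), so in this assay this change yields no move toward stronger inhibition, although its true size remains unknown. Compound 4 reaches only > 30000 nM, which is a limit of the assay and not a number. This position therefore accepts phenoxy without any measurable gain, and the series now holds a second reading that cannot be placed exactly: the limit of > 30000 nM in this assay, at which 2 of the 4 values shown sit.

On these data alone, whether a smaller group at this position, such as an amine, a methoxy or a carboxylic acid, would give a lower number than acetyl remains open, as does the question of how far a longer chain ending in a phenyl ring would differ from phenoxy. It is also unresolved whether phenoxy would fare differently alongside a chlorine on the same ring, and steps that would need the true values behind the limits cannot be read.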